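The compounds below may be only part of what the source reports. "The series", "measured", "known", "first", "only" and "open" are said of these compounds alone.

The compounds measured so far, all sharing one core and differing only in the ring that hangs from the double-bonded chain carbon:

Compound 1, `COc1ccc(CNC(=O)/C(C#N)=C/c2ccc(C)o2)cc1`. In a functional assay on NCI-H460 cells (Homo sapiens) for inhibition, read by MTT assay, with a stated time of 72 h (on this read-out lower numbers stand for stronger inhibition of growth and higher numbers for weaker inhibition of growth), compound 1 reaches only the limit of the assay, > 100000 nM.
Compound 2, `COc1ccc(CNC(=O)/C(C#N)=C/c2ccc(Cl)o2)cc1`. In this assay compound 2 gives 15000 nM.
Compound 3, `COc1ccc(CNC(=O)/C(C#N)=C/c2cc(Br)co2)cc1`. In this assay compound 3 also sits at the limit, > 100000 nM.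

Compound 3 therefore stands at the weak end of what has been measured, at the limit shared with compound 1 (the limit of > 100000 nM in this assay, at which 2 of the 3 values shown sit). From compound 2 the step is an at least 6.6-fold higher number from compound 2 to compound 3 (0.82 log units; beyond the scatter), while the step from compound 1 is a step that the two limits leave unreadable from compound 1 to compound 3.

Compound 4, `COc1ccc(CNC(=O)/C(C#N)=C/c2ccoc2)cc1`, is not yet measured. Its change from compound 3 is furan-3-yl in place of 4-bromofuran-2-yl on a double-bonded chain carbon bound to a double-bonded chain carbon. For the measured compounds named here, no measured step covers the loss of bromine together with the move of the attachment point; the only steps with a change on this ring, an at least 6.6-fold lower number from compound 1 to compound 2 (0.82 log units; beyond the scatter) and an at least 6.6-fold higher number from compound 2 to compound 3 (0.82 log units; beyond the scatter), show that small changes here can shift the read-out at least modestly in either direction. With compound 3 already at the limit, compound 4 is expected to remain weak, with the step of an at least 1.2-fold lower number from compound 3 to compound 4 (0.09 log units; that floor lies within the scatter) estimated as not clearly beyond the scatter. The estimate for compound 4 in this assay is 80000 nM, between 20000 nM and 300000 nM.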

Compound 4, concentration for 50% growth inhibition: 8000 nM
The estimate for compound 4 lay 10-fold (1.00 log units) above the measured number; measured number outside the range, below it.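

Compound 4 shows that this position does not need a substituent on the furan for growth inhibition in this assay: furan-3-yl in place of 4-bromofuran-2-yl gives an at least 12-fold lower number from compound 3 to compound 4 (1.09 log units; beyond the scatter), and furan-3-yl in place of 5-methylfuran-2-yl gives an at least 12-fold lower number from compound 1 to compound 4 (1.09 log units; beyond the scatter). Furan-3-yl in place of 5-chlorofuran-2-yl gives a 1.9-fold lower number from compound 2 to compound 4 (0.27 log units; within the scatter), so these two groups cannot be told apart here, and a halogen on the ring is neither needed, as compound 4 shows, nor enough, as compound 3 with its bromine shows. The two large steps give only a minimum size, because compound 1 and compound 3 each stand at a limit of the assay: the limit of > 100000 nM in this assay, at which 2 of the 4 values shown sit.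

The change from compound 3 to compound 4 both removes the bromine and moves the attachment point, so the shift cannot be assigned to either one alone, and a plain furan-2-yl group would be needed to separate the two. Also open, on these data alone, is how a furan-3-yl group carrying an amine or a carboxylic acid would read in this assay.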